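The source may hold more compounds than are shown below. What is called first, only, known or untested is meant among the compounds shown, and "the series" means these compounds.

Compound 1 `COc1nc(-c2ccsc2)ccc1[C@@H](c1ccccc1)[C@@](O)(CCN(C)C)c1cccc2ccccc12` is the parent of the step under consideration. In a toxicity assay on HeLa cells (Homo sapiens) for cytotoxicity (a lower number here means that less compound is tolerated, a higher number that more compound is tolerated), compound 1 gives only a limit, > 64 ug/mL, and not a number. Compound 2 `COc1ncc(-c2ccccc2)cc1[C@@H](c1ccccc1)[C@@](O)(CCN(C)C)c1ccccc1` gives 11.9 ug/mL in this assay, and compound 3 `COc1ncc(-c2ccccc2)cc1[C@@H](c1ccccc1)[C@@](O)(CCN(C)C)c1cccc(F)c1F` gives 28.1 ug/mL. Among the compounds with values here, the single directly measured step, a 2.4-fold higher number from compound 2 to compound 3 (0.37 log units; beyond the scatter), sits on the saturated carbon bearing the hydroxyl group and not on the aromatic ring. Compound 1 thus rests at the limit of > 64 ug/mL in this assay, at which 1 of the 3 values shown sits, at the high end of the three values shown, while compound 2 and compound 3 lie lower.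

Compound 4 `COc1nc(-c2cccc(F)c2)ccc1[C@@H](c1ccccc1)[C@@](O)(CCN(C)C)c1cccc2ccccc12` differs from compound 1 by 3-fluorophenyl in place of thiophen-3-yl on an aromatic carbon. Within the data shown here, no measured pair in this set changes the group at that position, so the step from compound 1 to compound 4 has no direct precedent, and the one step on record, the exchange of phenyl for 2,3-difluorophenyl from compound 2 to compound 3, was modest and lies elsewhere in the molecule. Compound 4 is therefore expected to move by about an at least 1.1-fold lower number from compound 1 to compound 4 (0.06 log units; that floor lies within the scatter), which is not expected to exceed the scatter in either direction. The estimate for compound 4 in this assay is 55 ug/mL, with a range from 20 ug/mL to 140 ug/mL, and a fair chance that only a limit is again reported.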

Compound 4, half-maximal cytotoxic concentration: 62.8 ug/mL
For compound 4 the middle estimate is 1.1-fold (0.06 log units) below the measured one, within the range that was stated.
By their numbers in this assay, from the lowest: compound 2; then compound 3; then compound 4. At a limit, above all of these: compound 1.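

In this assay, within the data shown here, 3-fluorophenyl in place of thiophen-3-yl on the aromatic carbon next to the ring nitrogen gives an at least 1.0-fold lower number from compound 1 to compound 4 (0.00 log units; that floor lies within the scatter), and this position now has a step of its own, which the earlier compounds did not provide. The step is a floor and not a size, because compound 1 stands at a limit and not at a number: the limit of > 64 ug/mL in this assay, at which 1 of the 4 values shown sits. Compound 4 gives 62.8 ug/mL as a true number, so the exchange of a five-membered aromatic ring with 1 hetero atom for a six-membered aromatic ring of carbon only has a measured end point. The floor of this step lies within the scatter and neither establishes nor excludes a real fall in the tolerated concentration.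

As far as these compounds go, the true distance between compound 1 and compound 4 stays open, as does the separate share of the ring exchange and of the fluorine, which a plain phenyl at this position would help to divide. Also open, from the compounds shown here alone, is how far this position tolerates a different kind of group, such as an amine or a carboxylic acid on the ring that enters here.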